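Swapping ethoxy for methoxymethyl on the side chain

A few compounds are considered here, and "the series" means these few. Any claim that something is new, unique, unknown or untested is made for them only; others in the source may bear on it.

Of the compounds shown here, three sharing one core have been measured in a functional assay (trachea) with Cavia porcellus as the target; on this read-out lower numbers stand for an effect already at smaller amounts and higher numbers for an effect only at larger amounts of compound. There, compound 1 `CCCn1c(=O)n(CCO)c(=O)c2[nH]cnc21` gives 510 nM, and compound 2 `CCCn1c(=O)n(CCOC)c(=O)c2[nH]cnc21` gives 700 nM. Compound 3 `CCCn1c(=O)n(CCOCC)c(=O)c2[nH]cnc21` gives 70 nM, the lowest number of the three and beyond the scatter from both others.

The next compound, compound 4 `CCCn1c(=O)n(CCCOC)c(=O)c2[nH]cnc21`, contains the same atoms as compound 3, joined differently: methoxymethyl in place of ethoxy on a saturated chain carbon, two bonds along the chain from an aromatic nitrogen. Methoxymethyl stands in place of ethoxy on a saturated chain carbon, two bonds along the chain from an aromatic nitrogen.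

Within the data shown here, no measured step makes this exact change, so the evidence is indirect. The step of a 1.4-fold higher number from compound 1 to compound 2 (0.14 log units; within the scatter) stays within the scatter, while a 7.3-fold lower number from compound 1 to compound 3 (0.86 log units; beyond the scatter) and a 10-fold lower number from compound 2 to compound 3 (1.00 log units; beyond the scatter) are both modest. So far, then, only compound 3, the one compound ending in ethoxy, stands apart. Compound 4 ends in methoxy, as compound 2 does, but its chain differs, so a partial return toward the higher numbers seems more likely than a full one.

In this assay the expected step is a 2.9-fold higher number from compound 3 to compound 4 (0.46 log units; beyond the scatter), a modest rise at most. For compound 4 the estimated value is 200 nM, with an expected range of 60 nM to 700 nM.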

Compound 4, half-maximal effective concentration: 2900 nM
Compound 4: the middle estimate sits 15-fold (1.16 log units) below what was measured, outside the stated range (above it).
By their numbers in this assay, from the lowest: compound 3; then compounds 1 and 2 (each within the scatter of the next); then compound 4.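

In this assay the same atoms joined differently do not give the same result: a 41-fold higher number from compound 3 to compound 4 (1.62 log units; beyond the scatter) is the largest step in this set, so at this position, on a saturated chain carbon, two bonds along the chain from an aromatic nitrogen, ethoxy and methoxymethyl are far from interchangeable even though they match in every count computed for them. Nor does the shared methoxy ending place compound 4 with compound 2, since a 4.1-fold higher number from compound 2 to compound 4 (0.62 log units; beyond the scatter) is beyond the scatter, as is a 5.7-fold higher number from compound 1 to compound 4 (0.75 log units; beyond the scatter), which leaves 3-methoxypropyl with the highest number of the four rather than with the 2-methoxyethyl and hydroxy compounds. Nothing measured here accounts for the gap between these isomeric side chains.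

The compounds shown leave open whether the low number of compound 3 is particular to 2-ethoxyethyl or would carry over to a longer ether such as 2-propoxyethyl. They also leave open whether the rise with 3-methoxypropyl follows the longer stretch before the oxygen, which a 3-hydroxypropyl or 3-ethoxypropyl chain could help to separate.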